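A few compounds are considered here, and "the series" means these few. Any claim that something is new, unique, unknown or untested is made for them only; others in the source may bear on it.

Compound 1 `COc1ccccc1Oc1c(N)nc(-c2cccc(C)c2)nc1OCCO`: 14700 nM
Compound 2 `COc1ccccc1Oc1c(N)nc(-c2cccc(Cl)c2)nc1OCCO`: 4170 nM

Going by the values given here, in a functional assay on SK-MEL-28 cells (Homo sapiens) for cytotoxicity, read by CCK-8 assay, with a stated time of 24 h (a lower number here means a stronger inhibitor, a higher number a weaker inhibitor), compound 2, at 4170 nM, holds the lower of the two numbers so far, which makes it the stronger inhibitor of this pair. The next compound to be tested is compound 3 `COc1ccccc1Oc1c(N)nc(-c2cccc(Br)c2)nc1OCCO`, and its difference from compound 2 is this: bromo in place of chloro on an aromatic carbon. In words, it has bromo in place of chloro on an aromatic carbon. Among the compounds with values here, only one measured step bears on this change: a 3.5-fold lower number from compound 1 to compound 2 (0.55 log units; beyond the scatter). That step was modest, and it swapped methyl for chloro on an aromatic carbon. A single step sets no trend, so only a small move is expected in this assay, slightly towards a lower number, and it may stay within the scatter. The expected step is a 1.3-fold lower number from compound 2 to compound 3 (0.11 log units; within the scatter). The estimate for compound 3 is 3200 nM, with an expected range from 1400 nM to 7500 nM.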

Compound 3, half-maximal inhibitory concentration: 4040 nM
Compound 3: middle estimate off by 1.3-fold (0.10 log units), on the low side, and the stated range covers the measured number.
By their numbers in this assay, from the lowest: compounds 3 and 2 (each within the scatter of the next); then compound 1.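

In this assay, bromo in place of chloro in the 3-chlorophenyl group gives a 1.0-fold lower number from compound 2 to compound 3 (0.01 log units; within the scatter) and so leaves the reading unchanged within the scatter: at this place on the ring, these two halogens cannot be told apart. Bromo in place of methyl gives a 3.6-fold lower number from compound 1 to compound 3 (0.56 log units; beyond the scatter) and so points the same way as the earlier change from methyl to chloro, which means that a second halogen now separates from methyl beyond the scatter. Nothing available explains why the two halogens match or why methyl stands apart from them.

Going by these compounds, only methyl, chloro and bromo have been seen at this place, so it remains open how a fluoro, a methoxy, a nitrile or an amine would read there. On these data alone, it is also open whether chloro and bromo would still match elsewhere on the ring.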